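Swapping a 4-fluorophenyl for a butyl on the ether oxygen

The compounds below may be only part of what the source reports. "The series", "measured", "known", "first", "only" and "open" are said of these compounds alone.

Measured compounds:
- Compound 1 `COc1cc2c(cc1CC=C(C)C)C(=O)C[C@@H](c1ccc(Oc3ccc(F)cc3)cc1)O2` gives 29% in a functional assay on HCT-116 cells (Homo sapiens) for inhibition, read by sulforhodamine B assay, with a stated time of 48 h, tested at 50 uM; on this read-out lower numbers stand for less inhibition of growth and higher numbers for more inhibition of growth at the one concentration tested.
- Compound 2 `COc1ccc([C@@H]2C/C(=N/OCc3cn(-c4ccc(NC(=O)c5ccccc5)cc4)nn3)c3cc(CC=C(C)C)c(OC)cc3O2)cc1` gives 8% in this assay.
- Compound 3 `COc1cc2c(cc1CC1OC1(C)C)C(=O)C[C@@H](c1ccc(O)cc1)O2` gives 97% in this assay.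

Compound 1 stands second highest of the three numbers. Its nearest neighbour is compound 2, whose number lies lower by more than the scatter; compound 3 sits far above it, again beyond the scatter. Compound 3 carries a free hydroxyl on the aromatic ring where compound 1 carries the 4-fluorophenoxy group, and compound 2 carries a much larger substituent in place of the carbonyl of the shared core; neither pair is a single-point comparison, so they only frame where compound 1 falls.

Compound 4 `CCCCOc1ccc([C@@H]2CC(=O)c3cc(CC=C(C)C)c(OC)cc3O2)cc1` has not been measured. It differs from compound 1 in one place: butyl in place of 4-fluorophenyl on an oxygen on an aromatic ring. Within the data shown here, no step between measured compounds matches this change, so the expectation rests on compound 1 alone. A modest rise or no change beyond the scatter is expected, and the step of a number 11 percentage points higher from compound 1 to compound 4 (beyond the scatter) is the estimated size. For compound 4 the expected value is 40%, within a range from 15% to 70%.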

Compound 4, percent growth inhibition at one concentration: 60%
Compound 4: middle estimate off by 20 percentage points, on the low side; low and high end bracket the measured number.
By their numbers in this assay, from the lowest: compound 2; then compound 1; then compound 4; then compound 3.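

Among the compounds shown, this is the only pair that differs in one place, so it links a change in this assay directly to the group on this ether oxygen. Putting butyl in place of 4-fluorophenyl gives a number 31 percentage points higher from compound 1 to compound 4 (beyond the scatter), so this position does not simply tolerate any group, and an open chain without a ring can go with more inhibition of growth than the aromatic group. No measurement here explains the step.

A single step cannot separate the loss of the ring, the loss of the fluorine and the presence of the chain itself. A plain phenyl, a propyl or a hexyl chain on the same oxygen would help tell these apart and show how the number follows chain length.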